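A Methoxy Swap at the Assay Limit

A few compounds are considered here, and "the series" means these few. Any claim that something is new, unique, unknown or untested is made for them only; others in the source may bear on it.

Of the compounds shown here, three sharing one core have been tested in a functional assay on MCF7 cells (Homo sapiens) for antiproliferative activity, read by MTT assay, with a stated time of 72 h; on this read-out higher numbers stand for weaker inhibition and lower numbers for stronger inhibition. Compound 1 is `COc1cc(-c2ncnn2-c2cccc(N)c2)cc(OC)c1OC`, and compound 1 gives > 10000 nM, which is a limit and not a number. Compound 2 is `COc1cc(-c2ncnn2-c2ccc([N+](=O)[O-])cc2)cc(OC)c1OC`, and compound 2 gives > 10000 nM, again a limit. Compound 3 is `COc1cc(-c2ncnn2-c2ccc(N)cc2)cc(OC)c1OC`, and compound 3 gives > 10000 nM, also a limit. The whole series therefore stands at one mark: the limit of > 10000 nM in this assay, at which 3 of the 3 values shown sit.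

Compound 4, `COc1ccc(-n2ncnc2-c2cc(OC)c(OC)c(OC)c2)cc1`, changes compound 3 in a single place: methoxy in place of amino on an aromatic carbon. A 4-aminophenyl becomes a 4-methoxyphenyl, with methoxy in place of amino on an aromatic carbon, para to a large group.

Two measured changes touch this same group. One is a step that the two limits leave unreadable from compound 1 to compound 3, and the other is a step that the two limits leave unreadable from compound 2 to compound 3. Among the compounds with values here, neither gives a size to carry over, and no tested compound yet carries methoxy at this place. The expectation is thus activity close to the limit in this assay, with some room toward stronger inhibition and a wide range. The expected change is an at least 1.6-fold lower number from compound 3 to compound 4 (0.22 log units; that floor lies within the scatter), a rough estimate only. For compound 4 the estimated value is 6000 nM, with an expected range from 300 nM to 20000 nM.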

Compound 4, half-maximal inhibitory concentration: 7400 nM
The estimate for compound 4 lay 1.2-fold (0.09 log units) below the measured number; low and high end bracket the measured number.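

Within the data shown here, compound 4, at 7400 nM, is the only compound here that gives a number rather than a limit in this assay, which shows that this place, on an aromatic carbon para to a large group, can carry a group that brings the read-out within the measured range. The comparisons can now be read in one direction, though only as floors: an at least 1.3-fold lower number from compound 3 to compound 4 (0.13 log units; that floor lies within the scatter), an at least 1.3-fold lower number from compound 2 to compound 4 (0.13 log units; that floor lies within the scatter), and, for the change on the aromatic nitrogen, an at least 1.3-fold lower number from compound 1 to compound 4 (0.13 log units; that floor lies within the scatter). All three steps have a floor within the usual scatter, and the steps among compounds 1, 2 and 3 still cannot be read, so the series has only a single number, while the other compounds share one mark: the limit of > 10000 nM in this assay, at which 3 of the 4 values shown sit.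

From the compounds shown here alone, how large the gain from methoxy really is stays open, since the true values of compounds 1, 2 and 3 lie somewhere past their limits. Also open, going by these compounds, is whether another group at this place, such as a hydroxyl, an ethoxy or a chlorine, would give a lower number than compound 4 does.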